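Swapping a Fluorophenylethyl Arm for a Phenylcyclopropyl Arm

A few compounds are considered here, and "the series" means these few. Any claim that something is new, unique, unknown or untested is made for them only; others in the source may bear on it.

Compound 1 `Cc1nc2c(c(-c3cc(F)c4c(c3C)CCCO4)c1[C@H](OC(C)(C)C)C(=O)O)CN(CCCc1ccc(F)cc1)CC2` was tested in an ADME assay on MT2 cells (Homo sapiens) for cytotoxicity, read by XTT assay, with a stated time of 4 days; on this read-out lower numbers stand for higher toxicity in this test and higher numbers for lower toxicity in this test. In this assay compound 1 gives only a limit, > 40000 nM, not a number. Compound 2 `Cc1ccc(-c2c3c(nc(C)c2[C@H](OC(C)(C)C)C(=O)O)CCN(Cc2ccccc2)C3)cc1` carries the shared core with a different arm on the ring amine and was run in the same test. There compound 2 also reaches only a limit, > 40000 nM. Both results sit at the limit of > 40000 nM in this assay, at which 2 of the 2 values shown sit, so the two measured compounds do not separate from each other at all. Compound 3 `Cc1nc2c(c(-c3cc(F)c4c(c3C)CCCO4)c1[C@H](OC(C)(C)C)C(=O)O)CN(CC1CC1c1ccccc1)CC2` has not yet been measured. It differs from compound 1 by 2-phenylcyclopropyl in place of 2-(4-fluorophenyl)ethyl on a saturated chain carbon bound to an amine nitrogen in a ring. Among the compounds with values here, no measured pair shows how such a change moves the read-out in this assay, so no shift beyond the usual scatter is expected. Compound 3 is expected to give about 40000 nM, within 20000 nM to 80000 nM, most likely reported again only as a limit. The expected step of a number no higher from compound 1 to compound 3 (the limit leaves the size open) is thus essentially none.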

Compound 3, half-maximal cytotoxic concentration: > 40000 nM
Compound 3 gave a limit, no number (the forecaster's own chance of this, stated with the estimate: 75%); the middle value lies on the limit itself.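

Compound 1 and compound 3 each give only a limit in this assay and no number, so the step from compound 1 to compound 3 cannot be read: the limit of > 40000 nM in this assay, at which 3 of the 3 values shown sit.

The compounds shown leave open whether 2-phenylcyclopropyl in place of 2-(4-fluorophenyl)ethyl changes the half-maximal cytotoxic concentration at all.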